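Fluoropyridinyl replacement on the ring amine of compound 1

This account rests on a few compounds, and the source may have more. Where it says the series, first, only, none or still open, it means among the compounds named here.

In an assay on isolated protein for inhibition of long-chain fatty acid transport protein 1 (Homo sapiens), read by scintillation counting, with a stated time of 20 min (on this read-out lower numbers stand for stronger inhibition and higher numbers for weaker inhibition), compound 1 `O=C(CN1CCN(c2ccc(F)cc2)CC1)Nc1nc2c(o1)CCCC2` gives 180 nM, the highest of the two numbers shown. The nearest measured neighbour, compound 2 `CC1CCc2sc(NC(=O)CN3CCN(c4ccc(F)cc4)CC3)nc2C1`, gives 26 nM in this assay, a step that lies beyond the scatter. Compound 3 `O=C(CN1CCN(c2ccncc2)CC1)Nc1nc2c(s1)CCCC2` in this assay reaches only the assay limit, > 1000 nM; this is a limit and not a number (the limit of > 1000 nM in this assay, at which 1 of the 3 values shown sits).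

Among the measured compounds shown here, no pair of measured compounds differs in one place only, so no single step is quantified. The change from compound 1 to compound 4 `O=C(CN1CCN(c2ccc(F)cn2)CC1)Nc1nc2c(o1)CCCC2` is 5-fluoropyridin-2-yl in place of 4-fluorophenyl on an amine nitrogen in a ring, in words: 5-fluoropyridin-2-yl in place of 4-fluorophenyl on an amine nitrogen in a ring. The fluorine is kept, one ring carbon becomes a nitrogen.

For the measured compounds named here, the only measured compound whose aromatic ring on the ring amine contains a nitrogen is compound 3, and it sits at the limit; its core, however, also differs from that of compound 1, so the two values show no isolated effect. A loss of some size beyond the scatter is expected, though smaller than a drop to the limit. Compound 4 is estimated at 400 nM in this assay, within 120 nM to 1500 nM, an expected step of a 2.2-fold higher number from compound 1 to compound 4 (0.35 log units; beyond the scatter).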

Compound 4, half-maximal inhibitory concentration in the long-chain fatty acid transport protein 1 assay: 100 nM
For compound 4 the middle estimate is 4.0-fold (0.60 log units) above the measured one; measured number outside the range, below it.
By their numbers in the long-chain fatty acid transport protein 1 assay, from the lowest: compound 2; then compounds 4 and 1 (each within the scatter of the next). At a limit, above all of these: compound 3.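

Among the compounds shown here, the first single-place step falls at this position: in the long-chain fatty acid transport protein 1 assay compound 1 gives 180 nM and compound 4 gives 100 nM with 5-fluoropyridin-2-yl in place of 4-fluorophenyl on an amine nitrogen in a ring, which is a 1.8-fold lower number from compound 1 to compound 4 (0.26 log units; within the scatter). On the core of compound 1, with the fluorine kept, a ring nitrogen in this aromatic ring, counted as one hydrogen-bond acceptor, is therefore tolerated in this assay. In a physicochemical assay for lipophilicity, in phosphate buffer, measured as octanol-water partition, at pH 7.4 (a higher number here means a more lipophilic compound, a lower number a more polar compound), compound 1 gives 3 and compound 4 gives 2.7 with the same change, which is a number 0.30 log units lower from compound 1 to compound 4 (within the scatter), so neither read-out separates the two groups.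

Still open, as far as these compounds go, is how other rings on the ring amine would read, for instance pyrimidin-2-yl with a second ring nitrogen or 5-chloropyridin-2-yl, and whether the same change on the core of compound 2 would give a step of similar size. Compound 3 stands at a limit and not a number, and it differs from compound 1 in more than one place, so the role of the ring nitrogen without the fluorine or on another core stays unread: the limit of > 1000 nM in the long-chain fatty acid transport protein 1 assay, at which 1 of the 4 values shown sits.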